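Thiourea analogues on a shared anilinoquinazoline core

The source may report more compounds than this note shows. Statements on the series, on what has been measured and on what is new or still open speak of the compounds shown alone.

Compound 1 `COc1cc2ncnc(Nc3ccc(F)c(Cl)c3)c2cc1OCCCCC(=O)Nc1ccc(S(N)(=O)=O)cc1`: 5020 nM
Compound 2 `NS(=O)(=O)c1ccc(NC(=S)Nc2ccc3ncnc(Nc4ccc(F)c(Cl)c4)c3c2)cc1`: 37600 nM

Of the compounds shown here, two have been measured in a functional assay on A-431 cells (Homo sapiens) for antiproliferative activity, read by MTT assay, with a stated time of 72 h; a higher number here means a weaker inhibitor, a lower number a stronger inhibitor. Compound 1 gives 5020 nM. Compound 2 gives 37600 nM, the higher of the two numbers, and its gap to compound 1 lies beyond the usual scatter. Within the data shown here, no single-site step connects these two measured compounds, so only their two values can be set side by side.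

Compound 3 `NS(=O)(=O)c1ccc(NC(=S)Nc2ccc3ncnc(Nc4ccc(Cl)c(C(F)(F)F)c4)c3c2)cc1` keeps the thiourea-linked sulfonamide arm of compound 2 and differs from it in one place: 4-chloro-3-(trifluoromethyl)phenyl in place of 3-chloro-4-fluorophenyl on a nitrogen on an aromatic ring. Among the measured compounds shown here, no measured pair shows the effect of this exchange, so the expectation for compound 3 rests on compound 2 alone. Compound 3 is estimated to sit close to compound 2 in this assay, with a step of a 1.1-fold higher number from compound 2 to compound 3 (0.03 log units; within the scatter) that is not expected to go clearly beyond the scatter in either direction. The estimate for compound 3 in this assay is 40000 nM, with a range from 10000 nM to 150000 nM.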

Compound 3, half-maximal inhibitory concentration: 18200 nM
Estimate against measurement, compound 3: 2.2-fold (0.34 log units) above; the measured number falls inside the stated range.
By their numbers in this assay, from the lowest: compound 1; then compound 3; then compound 2.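

In this assay, among these compounds, the exchange of 3-chloro-4-fluorophenyl for 4-chloro-3-(trifluoromethyl)phenyl on a nitrogen on an aromatic ring gives a 2.1-fold lower number from compound 2 to compound 3 (0.32 log units; beyond the scatter), and this is the first single-site reading, which the earlier pair of compounds could not provide. With the thiourea-linked sulfonamide arm held fixed, the number therefore responds to the aryl group on this nitrogen, and the entering group, with 11 heavy atoms against 8 in the group it replaces, brings a modest gain rather than a loss. No supporting data bear on the reason for this step.

Going by these compounds, what stays open is whether the same exchange would give a step of similar size on the arm carried by compound 1, and whether the direction would hold for other aryl groups on this nitrogen, such as a 3-bromophenyl or a 3-ethynylphenyl. Also open, on these data alone, is how the thiourea link itself contributes, since a urea or a plain amide in its place would be needed to separate the effect of the link from that of the aryl group.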